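A selenium-for-sulfur exchange in a cytotoxicity series

This account rests on a few compounds, and the source may have more. Where it says the series, first, only, none or still open, it means among the compounds named here.

Compound 1 `C[Se]/C(=N\C(=O)c1cccs1)NC(=O)c1cccs1` was tested in a functional assay on MCF7 cells (Homo sapiens) for cytotoxicity, read by MTT assay, with a stated time of 72 h (a lower number here means a stronger inhibitor of growth, a higher number a weaker inhibitor of growth), and gives 5640 nM. It stands at the lowest of the two numbers recorded; the nearest is compound 2 `CS/C(=N\C(=O)c1cc2ccccc2s1)NC(=O)c1cc2ccccc2s1`, whose value in this assay of 43400 nM lies beyond the scatter above it. Among the measured compounds shown here, no two measured compounds differ in a single place, so no isolated step can be read from this pair. Compound 3 `CS/C(=N\C(=O)c1cccs1)NC(=O)c1cccs1` has not yet been measured. It differs from compound 1 as follows: a group of 2 heavy atoms (1 carbon, 1 sulfur; no ring) in place of a group of 2 heavy atoms (1 carbon, 1 selenium; no ring), on a carbon with a double bond to nitrogen. For the measured compounds named here, with no measured step to rest on, the only pointer is that compound 2, which also carries the methylsulfanyl group but on a different core, gives the weaker number. The step from compound 1 to compound 3 is therefore expected to be a 2.1-fold higher number from compound 1 to compound 3 (0.33 log units; beyond the scatter), a modest weakening. Compound 3 is estimated at 12000 nM, within a range of 4000 nM to 40000 nM.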

Compound 3, concentration for total growth inhibition: 89000 nM
The estimate for compound 3 lay 7.4-fold (0.87 log units) below the measured number; measured number above the stated range.
By their numbers in this assay, from the lowest: compound 1; then compound 2; then compound 3.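

Among the compounds shown here, this exchange gives the first step that can be read in isolation at this position. On the carbon with a double bond to nitrogen, with the rest of compound 1 unchanged, putting methylsulfanyl in place of the selenium-bearing group gives a 16-fold higher number from compound 1 to compound 3 (1.20 log units; beyond the scatter) in this assay, so on this core the selenium-bearing compound is clearly the stronger inhibitor of growth and the change of a single atom is enough to produce a large step. Nothing measured here offers an explanation for the size of this step.

The compounds shown leave open whether the same exchange would give a step of similar size on the core of compound 2. They also leave open how a longer chain on the selenium, or an amine on this carbon, would compare with compound 1.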